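Plain Phenyl in Place of Dichlorophenyl: Expected Cytotoxicity

This account rests on a few compounds, and the source may have more. Where it says the series, first, only, none or still open, it means among the compounds named here.

Of the compounds shown here, three built on one shared core have been tested in a functional assay on DLD-1 cells (Homo sapiens) for cytotoxicity, read by colorimetric assay and MTT assay, with a stated time of 3 days, tested at 20 uM; on this read-out lower numbers stand for a stronger effect and higher numbers for a weaker effect at the one concentration tested. Compound 1 `Cc1ccccc1-n1cc(-c2ccccc2)c(-c2ccc3c(c2)NC(=O)CO3)n1` carries a 2-methylphenyl on an aromatic nitrogen, and in this assay compound 1 gives 62.9%. Compound 2 `O=C1COc2ccc(-c3nn(-c4ccc(Cl)cc4)cc3-c3ccccc3)cc2N1` carries a 4-chlorophenyl there, and compound 2 gives 47.1%. Compound 3 `O=C1COc2ccc(-c3nn(-c4cc(Cl)cc(Cl)c4)cc3-c3ccccc3)cc2N1` carries a 3,5-dichlorophenyl, and compound 3 gives 52.2%. On these numbers compound 3 sits with compound 2 within the scatter, the step being a number 5.1 percentage points higher from compound 2 to compound 3 (within the scatter), while the step of a number 10.7 percentage points lower from compound 1 to compound 3 (beyond the scatter) and the step of a number 15.8 percentage points lower from compound 1 to compound 2 (beyond the scatter) are beyond it. Both chlorine-bearing groups thus give a lower number, a stronger effect, than the methyl-bearing group.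

Compound 4 `O=C1COc2ccc(-c3nn(-c4ccccc4)cc3-c3ccccc3)cc2N1` has not been measured. It differs from compound 3 in one place: phenyl in place of 3,5-dichlorophenyl on an aromatic nitrogen. Within the data shown here, no measured step removes chlorines outright, so the expectation rests loosely on the spread among compounds 1, 2 and 3. Because the step of a number 5.1 percentage points higher from compound 2 to compound 3 (within the scatter) stays within the scatter, the count and placement of chlorines moved the value little in this small set, whereas the step of a number 15.8 percentage points lower from compound 1 to compound 2 (beyond the scatter) shows that exchanging the group on that nitrogen can shift the value modestly. For compound 4 the expected step is a number 2.8 percentage points higher from compound 3 to compound 4 (within the scatter), a small rise or none beyond the scatter. Compound 4 is therefore estimated at 55%, with a range from 42% to 68%.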

Compound 4, a percentage reported as activity, at one concentration (the size of the read-out at that concentration, not a potency): 47.7%
The estimate for compound 4 lay 7.3 percentage points above the measured number; the range from low to high includes it.
By their numbers in this assay, from the lowest: compounds 2, 4 and 3 (each within the scatter of the next); then compound 1.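

In this assay, among these compounds, the plain phenyl gives the first direct look at this group on the aromatic nitrogen without any chlorine: removing both chlorines is a number 4.5 percentage points lower from compound 3 to compound 4 (within the scatter) and removing the single chlorine is a number 0.6 percentage points higher from compound 2 to compound 4 (within the scatter) in this set, so chlorine is not required for a number of this size in these compounds. The methyl is what separates the compounds here, with a number 15.2 percentage points lower from compound 1 to compound 4 (beyond the scatter) for hydrogen in place of methyl, so the higher number of compound 1 goes with its methyl and not merely with a lack of chlorine. No measurement at hand explains why these groups match or differ.

Still open, as far as these compounds go, is whether a phenyl carrying a different kind of group, such as an amine, a carboxylic acid or a methoxy group, would move the value beyond the scatter in either direction. Also open, from the compounds shown here alone, is whether a 4-methylphenyl would go with a number like that of compound 1 or one like that of compound 4, which would show whether the result depends on where the methyl sits.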